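The compounds below may be only part of what the source reports. "The series", "measured", "known", "first", "only" and "open" are said of these compounds alone.

In a functional assay on MCF7 cells (Homo sapiens) for inhibition (on this read-out lower numbers stand for stronger inhibition and higher numbers for weaker inhibition), compound 1 (`Cc1cccc2cc([C@@H]3[C@@H](C(=O)c4ccccc4)C4(c5ccccc5-c5nc6ccccc6nc54)N4CSC[C@@H]34)c(Cl)nc12`) gives 12000000 nM, compound 2 (`Cc1cc(C)c2nc(Cl)c([C@@H]3[C@@H](C(=O)c4ccccc4)C4(c5ccccc5-c5nc6ccccc6nc54)N4CSC[C@@H]34)cc2c1`) gives 11000000 nM and compound 3 (`Cc1cccc2cc([C@@H]3[C@@H](C(=O)c4ccccc4)C4(c5ccccc5-c5nc6ccc(C(=O)c7ccccc7)cc6nc54)N4CSC[C@@H]34)c(Cl)nc12`) gives 13000000 nM. Compound 3 therefore stands within the scatter of both other compounds. Compound 4 (`Cc1cc(C)c2nc(Cl)c([C@@H]3[C@@H](C(=O)c4ccccc4)C4(c5ccccc5-c5nc6ccc(C(=O)c7ccccc7)cc6nc54)N4CSC[C@@H]34)cc2c1`) differs from compound 3 by methyl in place of hydrogen on an aromatic carbon. The same kind of change appears in a 1.1-fold lower number from compound 1 to compound 2 (0.04 log units; within the scatter), and the benzoyl change that separates the two series appears in a 1.1-fold higher number from compound 1 to compound 3 (0.03 log units; within the scatter). Both steps are small and lie within the scatter, so no step beyond the scatter is expected in this assay. The expected step is a 1.1-fold lower number from compound 3 to compound 4 (0.03 log units; within the scatter). Compound 4 is estimated at 12000000 nM, with an expected range from 7000000 nM to 20000000 nM.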

Compound 4, half-maximal inhibitory concentration: 11000000 nM
For compound 4 the middle estimate is 1.1-fold (0.04 log units) above the measured one, and the stated range covers the measured number.
By their numbers in this assay, from the lowest: compounds 2, 4, 1 and 3 (each within the scatter of the next).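

In this assay, methyl in place of hydrogen on an aromatic carbon, meta to a methyl group, gives a 1.2-fold lower number from compound 3 to compound 4 (0.07 log units; within the scatter), so this change now stays within the scatter on a second core: the same change on two cores in this assay, a 1.1-fold lower number (0.04 log units; within the scatter) from compound 1 to compound 2 and a 1.2-fold lower number (0.07 log units; within the scatter) from compound 3 to compound 4, 1.1-fold (0.03 log units) apart, within the scatter of two such steps The benzoyl change gives no change at the digits printed from compound 2 to compound 4 (within the scatter), so that change also stays within the scatter on two cores: the same change on two cores in this assay, a 1.1-fold higher number (0.03 log units; within the scatter) from compound 1 to compound 3 and no change at the digits printed (within the scatter) from compound 2 to compound 4, 1.1-fold (0.03 log units) apart, within the scatter of two such steps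

The compounds shown carry only hydrogen or methyl at this position. As far as these compounds go, whether an amine or a carboxylic acid here would produce a step beyond the scatter remains open.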